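A few compounds are considered here, and "the series" means these few. Any claim that something is new, unique, unknown or untested is made for them only; others in the source may bear on it.

Three compounds share one core and differ only in the group on one aromatic carbon. Compound 1 `Cc1cc(C2CCCCC2)c(S(C)(=O)=O)cc1C(=O)N=C(N)N` carries a cyclohexyl group there, and in a functional assay for inhibition of sodium/hydrogen exchanger (Oryctolagus cuniculus) (on this read-out higher numbers stand for weaker inhibition and lower numbers for stronger inhibition), compound 1 gives 22 nM. Compound 2 `Cc1cc(Sc2ccccc2)c(S(C)(=O)=O)cc1C(=O)N=C(N)N` carries a phenylsulfanyl group, and in this assay compound 2 gives 14 nM. Compound 3 `COc1cc(C)c(C(=O)N=C(N)N)cc1S(C)(=O)=O` carries a methoxy group, and in this assay compound 3 gives 16 nM, the second highest of the three numbers, though none of the three is told apart from the others by this read-out.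

Compound 4 `CCOc1cc(C)c(C(=O)N=C(N)N)cc1S(C)(=O)=O` is compound 3 with methyl in place of hydrogen on a saturated chain carbon bound to an oxygen on an aromatic ring; cut one bond further out, methoxy becomes ethoxy. For the measured compounds named here, no measured pair shows this exact change. Going by the values given here, the steps that bear on it are those that swapped the whole group on this aromatic carbon, a 1.4-fold lower number from compound 1 to compound 3 (0.14 log units; within the scatter) and a 1.1-fold higher number from compound 2 to compound 3 (0.06 log units; within the scatter), and both stayed within the scatter. A smaller extension of the methoxy group is therefore expected to give a step in this assay of no change at the digits printed from compound 3 to compound 4 (within the scatter), none beyond the scatter. Compound 4 is estimated at 16 nM, with a range from 7 nM to 36 nM.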

Compound 4, half-maximal inhibitory concentration: 19 nM
Compound 4: the middle estimate sits 1.2-fold (0.07 log units) below what was measured; measured number inside the range.
By their numbers in this assay, from the lowest: compounds 2, 3, 4 and 1 (each within the scatter of the next).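

In this assay, for the compounds shown here, methyl in place of hydrogen on a saturated chain carbon bound to an oxygen on an aromatic ring, which turns methoxy into ethoxy, is the first change here that extends the group rather than swapping it whole, and it gives a 1.2-fold higher number from compound 3 to compound 4 (0.07 log units; within the scatter). Ethoxy also stays close to the two other groups, with a 1.4-fold higher number from compound 2 to compound 4 (0.13 log units; within the scatter) and a 1.2-fold lower number from compound 1 to compound 4 (0.06 log units; within the scatter), so this read-out does not tell cyclohexyl, phenylsulfanyl, methoxy and ethoxy apart on this aromatic carbon. Nothing available explains why such different groups give such similar numbers.

Still open, as far as these compounds go, is whether an amine or a carboxylic acid on this aromatic carbon would stay within the scatter of these four compounds. The same question stands for a longer chain on the oxygen.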